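From methoxy to dimethylamino, with only limits in hand

The compounds below may be only part of what the source reports. "The series", "measured", "known", "first", "only" and "open" are said of these compounds alone.

Compound 1 `C=c1[nH]c(=O)/c(=C/c2ccccc2)[nH]c1=O`, compound 2 `C=c1[nH]c(=O)/c(=C/c2ccc(C(C)(C)C)cc2)[nH]c1=O` and compound 3 `C=c1[nH]c(=O)/c(=C/c2ccc(OC)cc2)[nH]c1=O` differ only in the group on the aromatic ring of the shared core. In a functional assay on Huh7.5.1 cells (Homo sapiens) for cytotoxicity, read by MTT assay, with a stated time of 72 h (on this read-out lower numbers stand for higher toxicity in this test and higher numbers for lower toxicity in this test), compound 1 gives > 20000 nM, which is a limit of the assay. Compound 2 gives > 20000 nM, also a limit. Compound 3 gives > 20000 nM, again a limit. No exact number is therefore known for compound 3, which stands with the others at the limit of > 20000 nM in this assay, at which 3 of the 3 values shown sit.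

Compound 4 `C=c1[nH]c(=O)/c(=C/c2ccc(N(C)C)cc2)[nH]c1=O` differs from compound 3 by dimethylamino in place of methoxy on an aromatic carbon, with dimethylamino in place of methoxy on an aromatic carbon. Among the measured compounds shown here, three measured steps bear on this change: a step that the two limits leave unreadable from compound 1 to compound 2, a step that the two limits leave unreadable from compound 1 to compound 3 and a step that the two limits leave unreadable from compound 2 to compound 3. None of them has a size that can be read, so no step beyond the usual scatter is expected in this assay, and no direction can be given. The estimated step is a step that the limit leaves unreadable from compound 3 to compound 4. For compound 4 the expected value is 25000 nM, with an estimated range from 10000 nM to 50000 nM.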

Compound 4, half-maximal cytotoxic concentration: > 20000 nM
Compound 4 was reported as a limit (the forecaster's own chance of this, stated with the estimate: 80%); the middle value does not contradict the limit.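

Compound 4 is again reported only as a limit of the assay, so no step between it and compound 1, compound 2 or compound 3 can be read: the limit of > 20000 nM in this assay, at which 4 of the 4 values shown sit.

The compounds shown leave open how far apart these four stand in this assay and whether any group on the aromatic ring gives an exact value there.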